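The compounds below may be only part of what the source reports. "The series", "measured", "known", "first", "only" and "open" are said of these compounds alone.

Compound 1 `O=C1N=C(c2ccc(Oc3ccccc3)cc2)S/C1=C\c1ccc(Oc2ccccc2)cc1` belongs to a small set of three compounds tested in an assay on cells for inhibition of Polyunsaturated fatty acid 5-lipoxygenase (Homo sapiens), read by HPLC, with stated times of 15 min and 10 min (on this read-out lower numbers stand for stronger inhibition and higher numbers for weaker inhibition), where compound 1 gives 650 nM. Compound 2 `COc1ccc(/C=C2\SC(c3ccc(C(=O)c4ccccc4)cc3)=NC2=O)cc1` gives 440 nM in this assay, and compound 3 `CCCOc1ccc(C2=NC(=O)/C(=C/c3ccc(OC)cc3)S2)cc1` gives 500 nM. The gaps between compound 1 and each of the other two are within the usual scatter of this assay, so the three numbers cannot be told apart.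

Compound 4 `O=C1N=C(c2ccc(Cl)cc2)S/C1=C\c1ccc(Oc2ccccc2)cc1` has not yet been measured. It differs from compound 1 in one place: chloro in place of phenoxy on an aromatic carbon. Among the compounds with values here, the only measured step that changes a group on that same aromatic ring is the one from compound 2 to compound 3, a 1.1-fold higher number from compound 2 to compound 3 (0.06 log units; within the scatter), a swap of propoxy for benzoyl that left the number essentially unchanged. Within the data shown here, no measured step exchanges phenoxy for chloro. Among the measured compounds shown here, with only that one step to lean on, no change beyond the scatter is expected in this assay, and compound 4 is estimated at 700 nM, with a range from 300 nM to 1600 nM, which corresponds to an expected step of a 1.1-fold higher number from compound 1 to compound 4 (0.03 log units; within the scatter).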

Compound 4, half-maximal inhibitory concentration: 170 nM
Compound 4: the middle estimate sits 4.1-fold (0.61 log units) above what was measured; the measured number lies below the stated range.
By their numbers in this assay, from the lowest: compound 4; then compounds 2, 3 and 1 (each within the scatter of the next).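

In this assay, within the data shown here, the group on this ring can matter: chloro in place of phenoxy gives a 3.8-fold lower number from compound 1 to compound 4 (0.58 log units; beyond the scatter) while the only earlier change on that ring, propoxy in place of benzoyl, gave a 1.1-fold higher number from compound 2 to compound 3 (0.06 log units; within the scatter) and did not separate its two compounds. The phenoxy group, with its own aromatic ring, is therefore not required at this place, para to a large group, for the number to fall, at least with the rest of compound 4 kept as in compound 1. No measurement here explains why chloro gives the lower number.

On these data alone, whether the gain comes from chloro itself or simply from the loss of phenoxy remains open, and a bare hydrogen, a methyl or an amine at the same place would help tell these apart. As far as these compounds go, it is also open whether chloro would give a similar step with the methoxy group of compound 3 on the other ring.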